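The compounds below may be only part of what the source reports. "The series", "measured", "known", "first", "only" and "open" are said of these compounds alone.

For the measured compounds named here, in a functional assay on HCT-116 cells (Homo sapiens) for antiproliferative activity, read by MTT assay, with a stated time of 48 h (on this read-out higher numbers stand for weaker inhibition and lower numbers for stronger inhibition), two compounds have numbers so far. Compound 1 (`COc1ccc(CN(C(=O)CSc2nc3ccccc3s2)c2cc(OC)c(OC)c(OC)c2)cc1C`) gives 17100 nM and compound 2 (`COc1ccc(CN(C(=O)CSc2nc3ccccc3s2)c2cc(OC)c(OC)c(OC)c2)cc1N=[N+]=[N-]`) gives 2860 nM as the lower of the two, so compound 2 stands as the stronger inhibitor of the pair. Compound 3 (`COc1ccc(CN(C(=O)CSc2nc3ccccc3s2)c2cc(OC)c(OC)c(OC)c2)cc1O`) differs from compound 2 in one group (hydroxy in place of azido on an aromatic carbon): hydroxy sits in place of azido on an aromatic carbon, ortho to a methoxy group, which turns 3-azido-4-methoxybenzyl into 3-hydroxy-4-methoxybenzyl. Going by the values given here, one measured step bears on this change, at the same carbon (a 6.0-fold lower number from compound 1 to compound 2 (0.78 log units; beyond the scatter)), and it shows that this assay can respond to a swap of group there. Among the compounds with values here, no measured compound yet carries hydroxy at that carbon, so this single step offers only a rough guide. A small further move toward a lower number is expected, smaller than that earlier step and possibly within the scatter. The expected change is a 1.9-fold lower number from compound 2 to compound 3 (0.28 log units; within the scatter) in this estimate. For compound 3 the estimated value is 1500 nM with an expected range of 300 nM to 8000 nM around it.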

Compound 3, half-maximal inhibitory concentration: 182 nM
For compound 3 the middle estimate is 8.2-fold (0.92 log units) above the measured one; the whole stated range lies above it.
By their numbers in this assay, from the lowest: compound 3; then compound 2; then compound 1.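

In this assay, putting hydroxy in place of azido gives a 16-fold lower number from compound 2 to compound 3 (1.20 log units; beyond the scatter), and that is a large step, so this aromatic carbon, ortho to a methoxy group, has far more influence on the read-out than the earlier swap of methyl for azido could reveal. Measured against the methyl group, hydroxy gives a 94-fold lower number from compound 1 to compound 3 (1.97 log units; beyond the scatter) in the same assay, which places the three groups tried at this carbon in a clear order, with hydroxy giving the strongest inhibition, then azido, then methyl. Hydroxy also brings a hydrogen-bond donor where azido has none, but this count only describes the swap, and no measurement here explains why the number falls so sharply.

The compounds shown leave open whether this gain is special to hydroxy or would also appear with an amine, a carboxylic acid or a longer chain such as ethoxy at this carbon. From the compounds shown here alone, all three compounds share the rest of their structure, so it also remains open whether hydroxy would have a similar effect on a different core.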